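The source may hold more compounds than are shown below. What is called first, only, known or untested is meant among the compounds shown, and "the series" means these compounds.

Compound 1 `CC(C)(C)C1=CC(=O)C=C(NCC(=O)O)C1=O`, compound 2 `CC(C)C[C@H](NC1=CC(=O)C=C(C(C)(C)C)C1=O)C(=O)O` and compound 3 `C[C@H](NC1=CC(=O)C=C(C(C)(C)C)C1=O)C(=O)O` share one core and differ only on a saturated chain carbon bound to an amine nitrogen and a carbonyl carbon. In a functional assay on A549 cells (Homo sapiens) for cytotoxicity, read by MTT assay, with a stated time of 72 h (on this read-out higher numbers stand for weaker inhibition and lower numbers for stronger inhibition), compound 1 gives > 200000 nM, which is a limit of the assay and not a number. Compound 3 gives > 200000 nM, which is also a limit. Among the measured compounds shown here, compound 2 gives 97900 nM, the only true number so far. Compound 3 therefore has no measured number of its own.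

Compound 4 `CSCC[C@H](NC1=CC(=O)C=C(C(C)(C)C)C1=O)C(=O)O` differs from it by (methylsulfanyl)methyl in place of hydrogen on a saturated chain carbon, two bonds along the chain from an amine nitrogen and a carbonyl carbon. The nearest guide is the isobutyl chain: adding it gives an at least 2.0-fold lower number from compound 1 to compound 2 (0.31 log units; beyond the scatter), and cutting it back gives an at least 2.0-fold higher number from compound 2 to compound 3 (0.31 log units; beyond the scatter). Both steps rest on (the limit of > 200000 nM in this assay, at which 2 of the 3 values shown sit), so their true size may be larger. The (methylsulfanyl)methyl group is also an open chain, so a modest move toward lower numbers is expected, estimated as an at least 1.6-fold lower number from compound 3 to compound 4 (0.22 log units; that floor lies within the scatter). Compound 4 is estimated at 120000 nM, with an expected range of 60000 nM to 200000 nM.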

Compound 4, half-maximal inhibitory concentration: > 200000 nM
Compound 4: a limit, no number; the forecaster's own chance of this, stated with the estimate: 40%; middle value at least 1.6-fold (0.22 log units) from the limit.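

In this assay compound 4 gives > 200000 nM, which is a limit of the assay and not a number. Putting (methylsulfanyl)methyl in place of isopropyl on the saturated chain carbon gives an at least 2.0-fold higher number from compound 2 to compound 4 (0.31 log units; beyond the scatter), so at this position an open chain does not by itself reach the number of compound 2: the isobutyl chain and the 2-(methylsulfanyl)ethyl chain are not interchangeable here. The steps to compound 4 from compound 1 and from compound 3 cannot be read because all three compounds sit at the same limit: the limit of > 200000 nM in this assay, at which 3 of the 4 values shown sit.

Going by these compounds, how far compound 1, compound 3 and compound 4 lie beyond that limit stays open. So does whether a longer carbon chain, a phenyl ring or an amine on this chain carbon would give a lower number than compound 2.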